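A Phenyl Group Replaces Hydroxy on the Shared Core

A few compounds are considered here, and "the series" means these few. Any claim that something is new, unique, unknown or untested is made for them only; others in the source may bear on it.

Measured so far:
compound 1, `CN1CCC[C@H]1[C@@H]1COc2c(N)cccc2O1`, 3900 nM
compound 2, `CN1CCC[C@H]1[C@@H]1COc2c(O)cccc2O1`, 3900 nM

Both compounds were tested in an assay on membranes from HEK293 cells for displacement of a labelled ligand from Neuronal acetylcholine receptor; alpha3/beta4 (Homo sapiens), with a stated time of 5 min; on this read-out higher numbers stand for weaker inhibition and lower numbers for stronger inhibition. Compound 2 stands level with compound 1 at the digits shown, and the one recorded step, no change at the digits printed from compound 1 to compound 2 (within the scatter), lies within the scatter; the two values therefore tell nothing about which compound is the tighter binder.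

Compound 3, `CN1CCC[C@H]1[C@@H]1COc2c(cccc2-c2ccccc2)O1`, has not yet been measured in this assay. Its change from compound 2 is phenyl in place of hydroxy on an aromatic carbon. Going by the values given here, no measured step involves a phenyl group, so nothing recorded bears directly on this change. Among the compounds with values here, the only step at the same aromatic carbon, from amino to hydroxy, stayed within the scatter, which gives a weak hint that this position tolerates variation, though a phenyl is a far larger group than either amino or hydroxy and could shift the value in either direction.

Compound 3 is therefore estimated at 5000 nM, within a range from 1000 nM to 25000 nM. The expected step, a 1.3-fold higher number from compound 2 to compound 3 (0.11 log units; within the scatter), is small, with the direction uncertain.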

Compound 3, inhibition constant: 2700 nM
Beside the measured number, compound 3's estimate is 1.9-fold (0.27 log units) above it; low and high end bracket the measured number.
By their numbers in this assay, from the lowest: compounds 3, 1 and 2 (each within the scatter of the next).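

The aromatic carbon where these groups sit now has a much larger group on it: phenyl, with 6 heavy atoms and a six-membered aromatic ring, replaces hydroxy, with 1 heavy atom and no ring. In this assay, this gives a 1.4-fold lower number from compound 2 to compound 3 (0.16 log units; within the scatter), and replacing amino with phenyl gives a 1.4-fold lower number from compound 1 to compound 3 (0.16 log units; within the scatter), so the earlier finding that amino and hydroxy read alike now extends to a group of a very different size, and also to one with 0 hydrogen-bond donors and 0 hydrogen-bond acceptors, where hydroxy has 1 of each. No supporting evidence is available to explain why these three groups give values that cannot be told apart.

The compounds shown leave open whether this level reading would hold for a carboxylic acid, for a longer chain such as n-butyl, or for a saturated ring such as cyclohexyl on the same aromatic carbon. They also leave open whether a phenyl carrying a substituent of its own, such as a methoxy group, would move the value beyond the scatter in either direction.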